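Methoxy to Trifluoromethyl: Predicting Compound 4

A few compounds are considered here, and "the series" means these few. Any claim that something is new, unique, unknown or untested is made for them only; others in the source may bear on it.

Measured compounds:
- compound 1, `NS(=O)(=O)c1ccccc1-c1cnc(C(=O)CCCCCCc2ccccc2)o1`: 1500 nM
- compound 2, `O=C(CCCCCCc1ccccc1)c1ncc(-c2ccccc2C(=O)C(F)(F)F)o1`: 5000 nM
- compound 3, `COC(=O)c1ccc(-c2cnc(C(=O)CCCCCCc3ccccc3)o2)cc1`: 40 nM

In an assay (Rattus norvegicus) for inhibition of Fatty-acid amide hydrolase 1 (Homo sapiens) (a lower number here means a stronger inhibitor, a higher number a weaker inhibitor), compound 3 gives the lowest number of the three, beyond the scatter against both compound 1 and compound 2. Compound 4, `O=C(CCCCCCc1ccccc1)c1ncc(-c2ccc(C(=O)C(F)(F)F)cc2)o1`, differs from compound 3 by trifluoromethyl in place of methoxy on a carbonyl carbon; seen one bond further out, a methoxycarbonyl becomes a (trifluoromethyl)carbonyl.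

Within the data shown here, only one measured step touches a (trifluoromethyl)carbonyl: a 3.3-fold higher number from compound 1 to compound 2 (0.52 log units; beyond the scatter). There the group enters in place of sulfamoyl, not methoxy, and on a different part of the shared core, so it is only a loose guide. Among the measured compounds shown here, no pair shows methoxy leaving directly. The change is therefore expected to shift this assay modestly, most likely toward a higher number, but the direction is uncertain.

Compound 4 is expected to give about 80 nM in this assay, within 25 nM to 300 nM, an expected step of a 2.0-fold higher number from compound 3 to compound 4 (0.30 log units; within the scatter).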

Compound 4, inhibition constant: 65 nM
Compound 4: the middle estimate sits 1.2-fold (0.09 log units) above what was measured, within the range that was stated.
By their numbers in this assay, from the lowest: compounds 3 and 4 (each within the scatter of the next); then compound 1; then compound 2.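

In this assay, trifluoromethyl in place of methoxy on a carbonyl carbon gives a 1.6-fold higher number from compound 3 to compound 4 (0.21 log units; within the scatter), so compound 3 and compound 4 cannot be told apart, even though the methoxy's hydrogen-bond acceptor leaves and a larger group enters. The (trifluoromethyl)carbonyl is therefore compatible with a low number at this position, something compound 2 alone could not show, since with the group on a different part of the shared core compound 2 gives 5000 nM while compound 4 gives 65 nM. No measurement is available to explain why this swap leaves the number within the scatter.

The compounds shown leave open how an amide or a carboxylic acid on this same carbonyl carbon would read in this assay. They also leave open whether a methoxycarbonyl on the part of the core that carries the group in compound 2 would give a number closer to that of compound 3 or of compound 2.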